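Adding hydroxy to the phenyl compound

The source may report more compounds than this note shows. Statements on the series, on what has been measured and on what is new or still open speak of the compounds shown alone.

Compound 1 `COc1ccc(S(=O)(=O)N2CCc3cccc(-c4ccco4)c32)cc1`: 42 nM
Compound 2 `COc1ccc(S(=O)(=O)N2CCc3cccc(-c4ccc(F)c(F)c4)c32)cc1`: 55.5 nM
Compound 3 `COc1ccc(S(=O)(=O)N2CCc3cccc(-c4ccccc4)c32)cc1`: 117 nM

In a functional assay on MKN-45 cells (Homo sapiens) for inhibition, with a stated time of 72 h (a lower number here means a stronger inhibitor, a higher number a weaker inhibitor), compound 3 gives the highest number of the three, 117 nM. Compound 4 `COc1ccc(S(=O)(=O)N2CCc3cccc(-c4ccc(O)cc4)c32)cc1` has hydroxy in place of hydrogen on an aromatic carbon, turning phenyl into 4-hydroxyphenyl (hydroxy in place of hydrogen on an aromatic carbon). Among the compounds with values here, none of the measured compounds carries hydroxy, so the evidence is indirect. The closest guide is a 2.1-fold higher number from compound 2 to compound 3 (0.32 log units; beyond the scatter), where the substituents on this same ring are lost. Replacing the ring itself gives a 2.8-fold higher number from compound 1 to compound 3 (0.44 log units; beyond the scatter). Both steps are modest, and they leave the unsubstituted phenyl with the highest number. A small move to a lower number is therefore expected, and the expected step is a 1.5-fold lower number from compound 3 to compound 4 (0.17 log units; within the scatter). The estimate for compound 4 is 80 nM, with an expected range of 30 nM to 220 nM.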

Compound 4, half-maximal inhibitory concentration: 82.6 nM
Beside the measured number, compound 4's estimate is 1.0-fold (0.01 log units) below it; measured number inside the range.
By their numbers in this assay, from the lowest: compounds 1, 2, 4 and 3 (each within the scatter of the next, the first and the last beyond it).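

In this assay, hydroxy in place of hydrogen, para to a large group, gives a 1.4-fold lower number from compound 3 to compound 4 (0.15 log units; within the scatter), so this position accepts the added group without a change beyond the scatter. Compound 4 also lies within the scatter of the other two compounds, with a 1.5-fold higher number from compound 2 to compound 4 (0.17 log units; within the scatter) and a 2.0-fold higher number from compound 1 to compound 4 (0.29 log units; within the scatter), whereas compound 3 lies beyond it from both. Nothing available here explains this result. The compounds shown leave open whether an amine or a carboxylic acid at this same place would give a similar number.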